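The compounds below may be only part of what the source reports. "The series", "measured", "known", "first", "only" and "open" are said of these compounds alone.

The compounds measured so far in a functional assay on HeLa cells (Homo sapiens) for inhibition, read by sulforhodamine B assay; a higher number here means a weaker inhibitor, a lower number a stronger inhibitor:

Compound 1 `O=C1C=C(NCc2ccccc2)C(=O)c2c1nc1n2[C@H]2OC[C@@H](O)[C@H]2OC1` gives > 8000 nM, which is a limit of this assay.
Compound 2 `O=C1C(NC2CCCC2)=CC(=O)c2c1nc1n2[C@H]2OC[C@@H](O)[C@H]2OC1` gives > 16000 nM, which is a limit of this assay.
Compound 3 `COc1ccccc1NC1=CC(=O)c2c(nc3n2[C@H]2OC[C@@H](O)[C@H]2OC3)C1=O` gives 7460 nM.

Compound 1 thus stands at a limit rather than at a number, and so does compound 2; only compound 3 carries a measured value. For the measured compounds named here, the one step that can be sized runs between compound 2 and compound 3: an at least 2.1-fold lower number from compound 2 to compound 3 (0.33 log units; beyond the scatter). Its size is bounded by the limit of > 16000 nM in this assay, at which 1 of the 3 values shown sits, at which compound 2 sits.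

Compound 4 `CCOc1ccccc1NC1=CC(=O)c2nc3n(c2C1=O)[C@H]1OC[C@@H](O)[C@H]1OC3` is the unmeasured compound. It differs from compound 1 in one place: 2-ethoxyphenyl in place of benzyl on an amine nitrogen.

Going by the values given here, no measured step covers exactly this change. The step from compound 2 to compound 3 is the nearest comparison, since there too an alkoxy-bearing phenyl entered on the amine nitrogen, and it brought only a modest improvement that ended at a weak number. With compound 1 sitting at the limit of > 8000 nM in this assay, at which 1 of the 3 values shown sits, the starting point is itself unknown, so the direction of the step cannot be fixed.

Compound 4 is therefore expected to land near compound 3, estimated at 9000 nM with a range from 4000 nM to 25000 nM. The expected step from compound 1 is a step that the limit leaves unreadable from compound 1 to compound 4, and a limit rather than a number is a real possibility.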

Compound 4, half-maximal inhibitory concentration: 6040 nM
Beside the measured number, compound 4's estimate is 1.5-fold (0.17 log units) above it; measured number inside the range.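

In this assay, setting 2-ethoxyphenyl in place of benzyl on the amine nitrogen gives an at least 1.3-fold lower number from compound 1 to compound 4 (0.12 log units; that floor lies within the scatter). This position now carries a second aryl group with an alkoxy substituent: compound 3 gives 7460 nM and compound 4 gives 6040 nM, so the ethoxy compound stays close to the methoxy compound, and both numbers remain weak. The real size of the change from benzyl cannot be read, because compound 1 stands at a limit and not at a number: the limit of > 8000 nM in this assay, at which 1 of the 4 values shown sits.

The compounds shown leave open whether the measured numbers depend on the alkoxy group at all or whether a plain phenyl on the same nitrogen would do as well. They also leave open whether a longer chain such as butoxy, or a ring carrying an amine or a carboxylic acid in place of the ethoxy group, would move the number well away from these values.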